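This account rests on a few compounds, and the source may have more. Where it says the series, first, only, none or still open, it means among the compounds named here.

Measured compounds in a functional assay on MCF7 cells (Homo sapiens) for antiproliferative activity, read by MTT assay, with a stated time of 72 h; on this read-out lower numbers stand for stronger inhibition and higher numbers for weaker inhibition:
compound 1, `CCCSc1nc(N/N=C/c2ccc(C)cc2)c2nnn(Cc3ccccc3)c2n1`, gives > 64000 nM, a limit of the assay.
compound 2, `CCCSc1nc(N/N=C/c2ccc(Br)cc2)c2nnn(Cc3ccccc3)c2n1`, gives > 64000 nM, a limit of the assay.

Compound 2 stands at the limit of this assay, so no number is known for it. The same holds for compound 1. The step from compound 1 to compound 2, a step that the two limits leave unreadable from compound 1 to compound 2, therefore has no readable size. Both values sit at the limit of > 64000 nM in this assay, at which 2 of the 2 values shown sit.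

Compound 3, `CCCSc1nc(N/N=C/c2ccc([N+](=O)[O-])cc2)c2nnn(Cc3ccccc3)c2n1`, carries the change (nitro in place of bromo on an aromatic carbon). Among the compounds with values here, the only measured step, bromo in place of methyl, rests on two limits and gives no guide to the size or direction of the step in this assay. Compound 3 is expected to show a step that the limit leaves unreadable from compound 2 to compound 3, with a real chance that again only a limit is returned. Compound 3 is expected at 80000 nM, in the range 20000 nM to 300000 nM.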

Compound 3, half-maximal inhibitory concentration: 11000 nM
For compound 3 the middle estimate is 7.3-fold (0.86 log units) above the measured one; measured number outside the range, below it.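

In this assay, the position on an aromatic carbon para to a large group now proves able to move the read-out, since nitro in place of bromo gives an at least 5.8-fold lower number from compound 2 to compound 3 (0.76 log units; beyond the scatter). Nitro in place of methyl gives an at least 5.8-fold lower number from compound 1 to compound 3 (0.76 log units; beyond the scatter), so the 4-nitrophenyl compound is the only one of the three with a number rather than a limit. Both steps give only a minimum size, and the step from methyl to bromo cannot be read, as compounds 1 and 2 each stand at a limit: the limit of > 64000 nM in this assay, at which 2 of the 3 values shown sit.

Going by these compounds, what an amine or a carboxylic acid at this same position would give remains open. Also open, on these data alone, is whether the step seen with nitro carries over to compounds with a longer chain on the sulfur.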